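Cyanoguanidine in place of thiourea on a pyridazinone chain

This account rests on a few compounds, and the source may have more. Where it says the series, first, only, none or still open, it means among the compounds named here.

Measured compounds:
compound 1, `CC(C)(C)/N=C(\S)NCCCCn1nc(-c2ccccc2)ccc1=O`, 33.6%
compound 2, `C/N=C(\S)NCCCCCCn1nc(C)ccc1=O`, -12.5%

Of the compounds shown here, two have been tested in a functional assay on the whole organism with Rattus norvegicus as the target, at a dose of 100 mg/kg; a higher number here means more inhibition at the dose given (going by the name of the read-out), a lower number less inhibition. Compound 1 gives 33.6%, the higher of the two numbers, while compound 2 gives -12.5%, a gap that lies beyond the scatter of this assay; compounds 1 and 2 differ in more than one place, so the reading is not traced to any single change.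

Compound 3, `C/N=C(\NC#N)NCCCCn1nc(-c2ccccc2)ccc1=O`, has not been measured. It differs from compound 1 by a group of 6 heavy atoms (3 carbon, 3 nitrogen; no ring) in place of a group of 7 heavy atoms (5 carbon, 1 nitrogen, 1 sulfur; no ring), on an amine nitrogen. Going by the values given here, no measured pair shows the effect of this change, and the phenyl-bearing core is kept. Compound 3 is expected to come out at 22%, within -8% to 45%. A step of a number 11.6 percentage points lower from compound 1 to compound 3 (beyond the scatter) is expected, a modest fall that would sit near the edge of the scatter.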

Compound 3, a percentage reported as inhibition, in the whole organism at one dose (the size of the read-out at that dose, not a potency): 79%
For compound 3 the middle estimate is 57 percentage points below the measured one, outside the stated range (above it).
By their numbers in this assay, from the lowest: compound 2; then compound 1; then compound 3.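

In this assay, going by these compounds alone, the first comparison that differs in one place gives a number 45.4 percentage points higher from compound 1 to compound 3 (beyond the scatter), with a cyanoguanidine group in place of the thiourea group on the amine nitrogen. With the chain and the core held constant, the group at this position alone can therefore move the reading well beyond the scatter, which the gap between compound 1 and compound 2, differing in more than one place, could not show. No available evidence bears on why this change raises inhibition at the dose given.

The change also replaces the tert-butyl end with a methyl, so the compounds shown do not separate the effect of that end from the effect of the cyanoguanidine. Going by these compounds, whether a urea at this position would read similarly, and whether the step holds on a longer chain, remains open.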